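Amide in place of urea at the pyridine-nitrogen-flanked carbon

The source may hold more compounds than are shown below. What is called first, only, known or untested is meant among the compounds shown, and "the series" means these compounds.

Three compounds of the series have numbers in an ADME assay on MT4 cells (Homo sapiens) for cytotoxicity, read by MTT assay; a lower number here means that less compound is tolerated, a higher number that more compound is tolerated. Compound 1 `Cc1ccc(-c2c(C)nc(Nc3nc4ccccc4s3)c(C)c2C(OC(C)(C)C)C(=O)O)cc1C` gives 6600 nM in this assay. Compound 2 `Cc1ccc(-c2c(C)nc(NC(=O)NC3CCCC3)c(C)c2C(OC(C)(C)C)C(=O)O)cc1C` gives 8000 nM. Compound 3 `Cc1nc(NC(=O)NC2CCCCC2)c(C)c(C(OC(C)(C)C)C(=O)O)c1-c1ccc2c(c1)CCCO2` gives 17000 nM. Compound 2 thus stands second highest of the three: its nearest neighbour is compound 1, whose number lies within the scatter of it, while compound 3 gives a higher number that lies beyond the scatter.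

Among the compounds with values here, the only single-point step measured so far is a 1.2-fold higher number from compound 1 to compound 2 (0.08 log units; within the scatter), which swaps one substituent on the ring nitrogen for another and leaves the number essentially where it was.

Compound 4 `Cc1ccc(-c2c(C)nc(C(=O)N(C)Cc3ccccc3)c(C)c2C(OC(C)(C)C)C(=O)O)cc1C` is not yet measured. Relative to compound 2 the change is benzyl(methyl)carbamoyl in place of (cyclopentylcarbamoyl)amino on an aromatic carbon, at the position next to the ring nitrogen and para to the 3,4-dimethylphenyl group. Within the data shown here, no measured step covers this exchange: the one step recorded kept the nitrogen-linked attachment intact, whereas here the attachment itself is replaced by a carbonyl-linked group. Among the measured compounds shown here, with that step as the only guide, and given the narrow spread of the three numbers, no shift beyond the scatter is expected for compound 4, so no change at the digits printed from compound 2 to compound 4 (within the scatter) is the estimated step. The estimate for compound 4 in this assay is 8000 nM, with a range from 3000 nM to 20000 nM.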

Compound 4, half-maximal cytotoxic concentration: 77000 nM
Compound 4: the middle estimate sits 9.6-fold (0.98 log units) below what was measured; the whole stated range lies below it.
By their numbers in this assay, from the lowest: compounds 1 and 2 (each within the scatter of the next); then compound 3; then compound 4.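

Exchanging a nitrogen-linked group for benzyl(methyl)carbamoyl on the aromatic carbon next to the ring nitrogen clearly moves the number in this assay, giving a 9.6-fold higher number from compound 2 to compound 4 (0.98 log units; beyond the scatter) and a 12-fold higher number from compound 1 to compound 4 (1.07 log units; beyond the scatter). This position is therefore not as flat as the exchange between two nitrogen-linked groups suggested, at a 1.2-fold higher number from compound 1 to compound 2 (0.08 log units; within the scatter); the tolerated concentration can change substantially here when the attachment itself is replaced. The exchange from compound 2 to compound 4 alters several things at once, replacing a five-membered non-aromatic ring with a six-membered aromatic ring and going from 2 hydrogen-bond donors to 0 hydrogen-bond donors, and no measurement at hand explains the higher number.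

The compounds shown leave open whether the step follows the carbonyl-linked attachment, the loss of the hydrogen-bond donors or the benzyl group. A benzylcarbamoyl that keeps the amide hydrogen, or a cyclopentylcarbamoyl on the same aromatic carbon, would separate these features, and a simple amine there would show how the nitrogen-linked side of the series reads without its larger substituent.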